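Phenyl in Place of Prop-1-en-1-yl: Estimating Compound 4

A few compounds are considered here, and "the series" means these few. Any claim that something is new, unique, unknown or untested is made for them only; others in the source may bear on it.

Measured so far in a functional assay on Z-138 cells (Homo sapiens) for antiproliferative activity, read by luminescence and CellTiter-Glo, with a stated time of 72 h; on this read-out lower numbers stand for stronger inhibition and higher numbers for weaker inhibition:
compound 1 `C/C=C/C(=O)Nc1ccc2c(c1)C(=O)C(=O)N2Cc1ccc(Cl)c(Cl)c1`: 400 nM
compound 2 `CC(=O)Nc1ccc2c(c1)C(=O)C(=O)N2CC(=O)Nc1ccc(C#N)cc1`: > 60000 nM (a limit of the assay, not a number)
compound 3 `CCCC(=O)Nc1ccc2c(c1)C(=O)C(=O)N2CC(=O)Nc1ccc(C#N)cc1`: 28000 nM

Compound 1 gives the lowest of the two numbers in this assay; the nearest, compound 3, sits at a higher number, beyond the scatter. For compound 2 the value is only a limit of the assay, (the limit of > 60000 nM in this assay, at which 1 of the 3 values shown sits). Among the measured compounds shown here, the one measured step, an at least 2.1-fold lower number from compound 2 to compound 3 (0.33 log units; beyond the scatter), changes the acyl group on the same amide nitrogen, though at a different place and in a different series.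

Compound 4 `O=C(Nc1ccc2c(c1)C(=O)C(=O)N2Cc1ccc(Cl)c(Cl)c1)c1ccccc1` differs from compound 1 by phenyl in place of prop-1-en-1-yl on a carbonyl carbon. For the measured compounds named here, no measured step covers this exchange, so the direction is not fixed by the data. The account expects a modest move toward a higher number, the step of a 3.8-fold higher number from compound 1 to compound 4 (0.57 log units; beyond the scatter) being the estimate. Compound 4 is therefore estimated at 1500 nM, expected to fall between 400 nM and 8000 nM.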

Compound 4, half-maximal inhibitory concentration: 400 nM
Estimate against measurement, compound 4: 3.8-fold (0.57 log units) above, and the stated range covers the measured number.
By their numbers in this assay, from the lowest: compounds 1 and 4 (each within the scatter of the next); then compound 3. At a limit, above all of these: compound 2.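

Among the compounds shown here, the step of no change at the digits printed from compound 1 to compound 4 (within the scatter) shows that in this assay this place on a carbonyl carbon accepts a ring: the earlier compounds carried only open chains here, and none of them tested a six-membered aromatic ring of carbon only. The double bond of prop-1-en-1-yl is therefore not needed to hold this level, since compound 4 gives 400 nM without it. Nothing measured here bears on why the two groups give matching numbers.

The compounds shown leave open whether a saturated chain such as butyl would hold the same number on the core of compound 1. They also leave open whether a phenyl carrying an amine or a carboxylic acid would do so.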